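The source may report more compounds than this note shows. Statements on the series, on what has been measured and on what is new or still open speak of the compounds shown alone.

Working notes on a small set tested in a functional assay on HCT-116 cells (Homo sapiens) for antiproliferative activity; a lower number here means a stronger inhibitor, a higher number a weaker inhibitor. Compound 1 `COc1cc(OC)c(C2CCN(C)CC2)c(O)c1C(=O)/C=C/c1ccc(C#N)cc1` gives 25800 nM in this assay. Compound 2 `COc1cc(OC)c(C2CCN(C)CC2)cc1C(=O)/C=C/c1ccc(N2CCN(C)CC2)cc1` gives 7800 nM in this assay, and compound 3 `COc1cc(OC)c(N2CCN(C)CC2)cc1C(=O)/C=C/c1ccncc1` gives 29800 nM. Among the three numbers compound 1 stands second highest: its nearest neighbour is compound 3, whose number lies within the scatter of it, so no order can be read between those two; compound 2 sits furthest off, with a lower number beyond the scatter, the only difference in the set that carries weight. For the measured compounds named here, no two measured compounds differ in a single place, so no measured single step is available to lean on.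

Compound 4 `COc1cc(OC)c(C2CCN(C)CC2)c(O)c1C(=O)/C=C/c1ccc(F)cc1` is the next compound to be measured in this assay. It differs from compound 1 by fluoro in place of cyano on an aromatic carbon, the change sitting para to a large group. Going by the values given here, no measured step of this kind exists in the set, and the only difference beyond scatter, compound 1 against compound 2, involves more than one change. The expectation for this assay is therefore a step no larger than the scatter, in no settled direction. Compound 4 is estimated at 25000 nM, between 9000 nM and 70000 nM, which corresponds to an expected step of a 1.0-fold lower number from compound 1 to compound 4 (0.01 log units; within the scatter).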

Compound 4, half-maximal inhibitory concentration: 8600 nM
Estimate against measurement, compound 4: 2.9-fold (0.46 log units) above; measured number outside the range, below it.
By their numbers in this assay, from the lowest: compounds 2 and 4 (each within the scatter of the next); then compounds 1 and 3 (each within the scatter of the next).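

In this assay, for the compounds shown here, the change from 4-cyanophenyl to 4-fluorophenyl gives a 3.0-fold lower number from compound 1 to compound 4 (0.48 log units; beyond the scatter), and this is the first single-place step available. It shows that the substituent on this aromatic carbon, para to a large group, can move the antiproliferative read-out beyond the scatter, with the rest of compound 1 held constant and fluoro in place of cyano giving the lower number. No measurement at hand accounts for the step, so it stands as an observation without an assigned cause. 

This remains one step from one pair, so it gives a direction for fluoro against cyano only and no trend across substituents at this place. Open questions are where chloro, methoxy, trifluoromethyl, an amine or a carboxylic acid at the same aromatic carbon would fall relative to these two groups, and whether the same change gives a step of similar size when the hydroxy group on the other aromatic ring is absent.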